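This account rests on a few compounds, and the source may have more. Where it says the series, first, only, none or still open, it means among the compounds named here.

Of the compounds shown here, three have so far been measured in a functional assay on NCI-H226 cells (Homo sapiens) for inhibition (a lower number here means a stronger inhibitor of growth, a higher number a weaker inhibitor of growth), and they spread widely. Compound 1 (`Nc1ccc(-c2nc3ccc(F)cc3s2)cc1I`) gives 70 nM and stands second highest of the three numbers. Compound 3 (`Nc1ccc(-c2nc3cc(F)ccc3s2)cc1Cl`) lies lower at 30 nM with a gap beyond the scatter. Compound 2 (`Cc1cc(-c2nc3c(F)cccc3s2)ccc1N`) lies much higher at 5500 nM and that gap is also beyond the scatter.

The account now turns to compound 4 (`Cc1cc(-c2nc3ccc(F)cc3s2)ccc1N`), which has not yet been measured. It departs from compound 1 by a single change: methyl in place of iodo on an aromatic carbon with methyl in place of iodo on an aromatic carbon, ortho to an amino group. Going by the values given here, no measured pair of compounds isolates this swap, so the evidence for its size is thin. Among the compounds with values here, compound 2 is the only measured compound that carries a methyl group, and its 5500 nM is the highest number of the three. That one result points towards weaker growth inhibition, though it cannot settle the direction on its own.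

A moderate weakening is therefore expected, with an estimated 3.6-fold higher number from compound 1 to compound 4 (0.55 log units; beyond the scatter) as the likely outcome. In this assay compound 4 is estimated at 250 nM with an expected range from 40 nM to 1500 nM as the span of likely results.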

Compound 4, concentration for 50% growth inhibition: 60300 nM
The estimate for compound 4 lay 240-fold (2.38 log units) below the measured number, and the stated range ends below it.
By their numbers in this assay, from the lowest: compound 3; then compound 1; then compound 2; then compound 4.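

In this assay, going by these compounds alone, methyl in place of iodo on the aromatic carbon ortho to an amino group is a large step, an 860-fold higher number from compound 1 to compound 4 (2.94 log units; beyond the scatter), and it gives the first direct reading of this position, which no earlier pair of compounds had isolated. The change swaps one heavy atom for one heavy atom and leaves the counts of rings, hydrogen-bond donors, hydrogen-bond acceptors and net charge untouched, yet growth inhibition is far weaker, so these counts alone do not capture what matters at this carbon. Nothing available here bears on why these two groups differ so sharply.

On these data alone, this single step fixes only the two ends of one comparison, so it remains open whether a bromo group, an ethyl group or a plain hydrogen on the same carbon would sit close to compound 1, close to compound 4 or somewhere between them. Within the data shown here, it also remains open whether a step of this size would recur with the fluoro group elsewhere on the shared core, since only this one pair isolates the change.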